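The source may hold more compounds than are shown below. What is called first, only, known or untested is meant among the compounds shown, and "the series" means these compounds.

Compound 1 `CC(C)=CCC[C@]1(C)/C=C/[C@@H](OC(=O)C=C(C)C)[C@](C)(O)/C=C/C(=O)/C(CF)=C\C1`: 240 nM
Compound 2 `CC(=O)O[C@]1(C)/C=C/C(=O)/C(CO)=C\C[C@](C)(CCC=C(C)C)/C=C/[C@H]1OC(=O)C=C(C)C`: 2320 nM

In a functional assay on MCF7 cells (Homo sapiens) for antiproliferative activity, read by MTT assay, with a stated time of 48 h (on this read-out higher numbers stand for weaker inhibition and lower numbers for stronger inhibition), compound 1 gives 240 nM, the lower of the two numbers, and compound 2 gives 2320 nM, a gap beyond the usual scatter. Compound 3 `CC(C)=CCC[C@]1(C)/C=C/[C@@H](OC(=O)C=C(C)C)[C@](C)(O)/C=C/C(=O)/C(C=O)=C\C1` has formyl in place of fluoromethyl on a double-bonded ring carbon of the core of compound 1: formyl in place of fluoromethyl on a double-bonded ring carbon. Among the compounds with values here, no measured pair differs in only one place, so nothing measured sizes this change directly. A moderate move toward a higher number in this assay is expected, though it may not clear the scatter. The estimated step is a 2.3-fold higher number from compound 1 to compound 3 (0.36 log units; beyond the scatter). For compound 3, the estimated value is 550 nM, with an expected range of 140 nM to 2200 nM.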

Compound 3, half-maximal inhibitory concentration: 12600 nM
Beside the measured number, compound 3's estimate is 23-fold (1.36 log units) below it; the measured number lies above the stated range.
By their numbers in this assay, from the lowest: compound 1; then compound 2; then compound 3.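

Within the data shown here, this is the first direct measure of a change at this double-bonded ring carbon: in this assay, formyl in place of fluoromethyl gives a 53-fold higher number from compound 1 to compound 3 (1.72 log units; beyond the scatter), a large step. The number in this assay therefore depends strongly on the group at this position, even though both groups have the same number of heavy atoms. Nothing shown explains the size of this step. On these data alone, how an aminomethyl group or a carboxylic acid would fare at this carbon remains open. A single step also cannot show whether fluoromethyl is especially favourable or formyl especially unfavourable.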